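A Longer Unsaturated Chain in Place of the Hexyl End

The source may hold more compounds than are shown below. What is called first, only, known or untested is meant among the compounds shown, and "the series" means these compounds.

Of the compounds shown here, three have so far been tested in an in vitro assay on Sf9 cells for inhibition of CAAX prenyl protease 2 (Homo sapiens), tested at 10 uM; on this read-out lower numbers stand for less inhibition and higher numbers for more inhibition at the one concentration tested (going by the name of the read-out). Compound 1 `CCCCCCCCCCCCCCCC(=O)NCCC(=O)Nc1ccc(C(=O)N[C@@H](CCSC)C(=O)OC)cc1` gives 15%, and compound 2 `CCCCCCCCCCCCCCCC(=O)NCC(=O)Nc1ccc(C(=O)N[C@@H](CCSC)C(=O)OC)cc1` gives 22%; these two values lie within the usual scatter of each other. Compound 3 `CCCCCCCCCCCCCC(=O)NCCC(=O)Nc1cccc(S(=O)(=O)Nc2cccc(C)c2C)c1` is recorded only as a limit of the assay rather than a number, < 5% (the limit of < 5% in this assay, at which 1 of the 3 values shown sits).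

Compound 4 `CCCCCCCC/C=C\CCCCCCCC(=O)NCCC(=O)Nc1cccc(S(=O)(=O)Nc2cccc(C)c2C)c1` has not yet been measured. It differs from compound 3 in one place: dec-1-en-1-yl in place of hexyl on a saturated chain carbon, seven bonds along the chain from a carbonyl carbon. Among the compounds with values here, no measured pair among the three compounds shows how such a change moves this read-out, and compound 3 itself carries only a limit. The expectation is a small step from compound 3 to compound 4 in this assay, a number at least 3 percentage points higher from compound 3 to compound 4 (that floor lies within the scatter), with inhibition staying low. Compound 4 is estimated at 8%, most likely between 0% and 25%, and it may again be reported only as a limit.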

Compound 4, a percentage reported as inhibition, at one concentration (the size of the read-out at that concentration, not a potency): < 5%
Compound 4 gave a limit, no number; the forecaster's own chance of this, stated with the estimate: 50%; middle value at least 3 percentage points from the limit.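

Compound 3 and compound 4 both sit at a limit of the assay rather than a number, so no step between them can be read: the limit of < 5% in this assay, at which 2 of the 4 values shown sit.

On these data alone, whether dec-1-en-1-yl in place of hexyl changes inhibition at all in this assay stays open.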